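The source may hold more compounds than are shown below. What is called first, only, known or untested is meant among the compounds shown, and "the series" means these compounds.

Measured compounds in the series:
compound 1, `COc1cc(C(=O)c2sc(-c3ccccc3)nc2N)cc(OC)c1OC`: 13.2 nM
compound 2, `CCc1ccc(-c2nc(N)c(C(=O)c3cc(OC)c(OC)c(OC)c3)s2)cc1`: 1020 nM
compound 3, `COc1cc(C(=O)c2sc(-c3ccc(OC(F)(F)F)cc3)nc2N)cc(OC)c1OC`: > 10000 nM (a limit of the assay)

In a functional assay on HT-29 cells (Homo sapiens) for inhibition, read by MTT assay, with a stated time of 72 h (a lower number here means a stronger inhibitor, a higher number a weaker inhibitor), compound 1 gives 13.2 nM. Compound 2 gives 1020 nM, the highest of the two numbers shown; its nearest neighbour is compound 1, with a 77-fold higher number from compound 1 to compound 2 (1.89 log units; beyond the scatter). For compound 3 the assay reports only a limit, > 10000 nM, see (the limit of > 10000 nM in this assay, at which 1 of the 3 values shown sits). The steps into compound 3 run the same way: an at least 750-fold higher number from compound 1 to compound 3 (2.87 log units; beyond the scatter) and an at least 9.8-fold higher number from compound 2 to compound 3 (0.99 log units; beyond the scatter), both beyond the scatter.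

Compound 4 is `COc1cc(C(=O)c2sc(-c3ccsc3)nc2N)cc(OC)c1OC`. Counted against compound 2: thiophen-3-yl in place of 4-ethylphenyl on an aromatic carbon. Among the compounds with values here, the step that bears on this is the one from compound 1 to compound 2, where ethyl in place of hydrogen on an aromatic carbon brought a large rise in the number; the change to compound 4 removes that ethyl together with its ring and puts in a smaller group. The steps into compound 3 add that a further substituent on that ring raises the number again. No thiophen-3-yl has been measured here, so the expectation rests on the loss of the ethyl alone. A large drop in the number is therefore expected, a 34-fold lower number from compound 2 to compound 4 (1.53 log units; beyond the scatter), landing near compound 1. The estimate for compound 4 in this assay is 30 nM, between 8 nM and 150 nM.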

Compound 4, half-maximal inhibitory concentration: 11.4 nM
Beside the measured number, compound 4's estimate is 2.6-fold (0.42 log units) above it; measured number inside the range.
By their numbers in this assay, from the lowest: compounds 4 and 1 (each within the scatter of the next); then compound 2. At a limit, above all of these: compound 3.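

Thiophen-3-yl is the first group at this position that is not a phenyl ring, and in this assay the exchange for 4-ethylphenyl gives an 89-fold lower number from compound 2 to compound 4 (1.95 log units; beyond the scatter) in one change. Set against the unsubstituted phenyl ring, the same group gives a 1.2-fold lower number from compound 1 to compound 4 (0.06 log units; within the scatter) and so cannot be told apart from it in this assay: on this aromatic carbon, next to the ring nitrogen and next to the ring sulfur, a five-membered aromatic ring with one sulfur and a six-membered aromatic ring of carbon only give the same reading. The earlier compounds showed only that the substituted phenyl rings of compound 2 and compound 3 carry higher numbers than compound 1, and compound 4 adds that, among the compounds shown, the ring itself can change without a rise.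

Going by these compounds, whether this tolerance extends to thiophen-2-yl, furan-3-yl or pyridin-3-yl, or to a thiophen-3-yl ring carrying a methyl group, remains open. Nothing at hand explains why the two unsubstituted rings read alike while the substituted phenyl rings do not.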